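Gem-dimethyl amide replaces aminoacetamide on the shared core

The compounds below may be only part of what the source reports. "The series", "measured", "known", "first", "only" and "open" are said of these compounds alone.

The account follows a single change on the shared core. Compound 1, `N#Cc1c(-c2ccc(Br)cc2)nc2cnccc2c1NCC(N)=O`, was examined in a physicochemical assay for lipophilicity, read by HPLC, at pH 7.5 (on this read-out lower numbers stand for lower lipophilicity and higher numbers for higher lipophilicity), where compound 1 gives 1.9. Compound 3, `CC[C@@H](Nc1c(C#N)c(-c2ccc(-c3ccccc3CO)cc2)nc2cnccc12)C(N)=O`, gives 2.1 in this assay, a number within the scatter of compound 1. Compound 2, `CCCCC(Nc1c(C#N)c(-c2ccc(-c3ccccc3OCC)cc2)nc2cnccc12)C(N)=O`, gives 3.6, which stands beyond the scatter and higher than compound 1. Going by the values given here, no two of the measured compounds differ in one place only, so no single-point step is known.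

Compound 4, `CC(C)(CC(N)=O)c1c(C#N)c(-c2ccc(Br)cc2)nc2cnccc12`, is not yet measured. It differs from compound 1 as follows: a group of 7 heavy atoms (5 carbon, 1 nitrogen, 1 oxygen; no ring) in place of a group of 5 heavy atoms (2 carbon, 2 nitrogen, 1 oxygen; no ring), on an aromatic carbon. The group that enters carries five carbon against two in the group that leaves, and one nitrogen and one hydrogen-bond donor fewer.

For this assay the expectation is a rise beyond the scatter. The step from compound 1 to compound 4 is estimated at a number 1.00 log units higher from compound 1 to compound 4 (beyond the scatter), because compound 2 with its longer chain reaches 3.6 while compound 1 sits at 1.9. Compound 4 is expected to give about 2.9, within a range from 2.3 to 3.5.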

Compound 4, distribution coefficient: 2.1
The estimate for compound 4 lay 0.80 log units above the measured number; the whole stated range lies above it.
By their numbers in this assay, from the lowest: compounds 1, 3 and 4 (each within the scatter of the next); then compound 2.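

In this assay, going by these compounds alone, the change on this aromatic carbon, opposite the ring nitrogen, comes to a number 0.20 log units higher from compound 1 to compound 4 (within the scatter), the first single-place step on the shared core, which the earlier compounds, differing in more than one place, could not give. With the 4-bromophenyl group and the cyano group kept, the group of 7 heavy atoms (5 carbon, 1 nitrogen, 1 oxygen), with 1 hydrogen-bond donor, thus stands in place of (carbamoylmethyl)amino, with 2 hydrogen-bond donors, and the two compounds are not separated on this read-out. Nothing among the data shown accounts for this outcome.

Within the data shown here, the single step does not tell which part of the exchange matters, the added carbon or the lost nitrogen, nor whether the result would hold for a longer chain, an amine or a carboxylic acid on this same aromatic carbon. It also leaves open whether the step would stay the same if the 4-bromophenyl group gave way to a biphenyl group such as those of compound 2 and compound 3.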